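Nitro for chloro on the aryl ring: expected growth inhibition

The compounds below may be only part of what the source reports. "The series", "measured", "known", "first", "only" and "open" are said of these compounds alone.

Measured so far:
compound 1, `Cc1cccc(-n2nc(-c3ccccc3)c(C=O)c2/N=C/N(C)C)c1`: 8900 nM
compound 2, `CN(C)/C=N/c1c(C=O)c(-c2ccccc2)nn1-c1cccc(Cl)c1`: 6400 nM

In a functional assay on NPC-TW01 cells (Homo sapiens) for inhibition, read by MTT assay, with a stated time of 72 h (on this read-out lower numbers stand for stronger inhibition of growth and higher numbers for weaker inhibition of growth), compound 1 gives 8900 nM and compound 2 gives 6400 nM. Going by the values given here, the one step known, chloro in place of methyl on an aromatic carbon, is a 1.4-fold lower number from compound 1 to compound 2 (0.14 log units; within the scatter), so the two numbers lie within the scatter of each other and compound 2 cannot be ranked against compound 1 on these data.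

Compound 3, `CN(C)/C=N/c1c(C=O)c(-c2ccccc2)nn1-c1cccc([N+](=O)[O-])c1`, has not been measured. It differs from compound 2 as nitro in place of chloro on an aromatic carbon. Among the compounds with values here, no measured compound carries a nitro group, so the only step that bears on this change is the exchange of substituents at the same aromatic carbon, a 1.4-fold lower number from compound 1 to compound 2 (0.14 log units; within the scatter), which stayed within the scatter. From the compounds shown here alone, on that basis no step beyond the scatter is expected from compound 2 to compound 3 in this assay, in either direction; the range is kept wide because the nitro group itself is untested.

The expected step is a 1.1-fold lower number from compound 2 to compound 3 (0.03 log units; within the scatter). For compound 3 the estimate is 6000 nM, with a range from 2500 nM to 15000 nM.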

Compound 3, concentration for 50% growth inhibition: 36700 nM
The estimate for compound 3 lay 6.1-fold (0.79 log units) below the measured number; the whole stated range lies below it.
By their numbers in this assay, from the lowest: compounds 2 and 1 (each within the scatter of the next); then compound 3.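

In this assay, this place on the aromatic ring does respond to its substituent: nitro in place of chloro gives a 5.7-fold higher number from compound 2 to compound 3 (0.76 log units; beyond the scatter), and nitro in place of methyl gives a 4.1-fold higher number from compound 1 to compound 3 (0.62 log units; beyond the scatter). The earlier step, a 1.4-fold lower number from compound 1 to compound 2 (0.14 log units; within the scatter), had shown no separation between methyl and chloro, so the 3-nitrophenyl compound is now the only one of the three that stands apart, with weaker inhibition of growth than either compound 1 or compound 2, which still cannot be ranked against each other. Nothing at hand gives a reason for the separation of nitro from the other two groups.

Three substituents at a single place cannot show whether the weaker inhibition of growth belongs to nitro alone or would also come with other groups there, such as an amine, a nitrile or a carboxylic acid. From the compounds shown here alone, it also stays open whether nitro would give a step of similar size elsewhere on the same ring, or with a group other than phenyl on the rest of the shared core.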